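Cytotoxicity limits across a quinolone ester pair

This account rests on a few compounds, and the source may have more. Where it says the series, first, only, none or still open, it means among the compounds named here.

Among the compounds with values here, compound 1 `CCOC(=O)c1c(-c2cccc(OC)c2)[nH]c2cc(OC)ccc2c1=O` is the first measured member; in an ADME assay on HepG2 cells (Homo sapiens) for cytotoxicity, read by luminescence, with a stated time of 72 h (a lower number here means that less compound is needed, a higher number that more compound is needed for the effect), compound 1 gives > 21500 nM, which is a limit of the assay and not a number. Compound 2 `CCOC(=O)c1c(-c2cccc(Oc3ccccc3)c2)[nH]c2cc(OC)ccc2c1=O` differs from compound 1 by phenyl in place of methyl on an oxygen on an aromatic ring. In this assay compound 2 gives > 21500 nM, again a limit. The step that the two limits leave unreadable from compound 1 to compound 2 therefore cannot be sized, because the limit of > 21500 nM in this assay, at which 3 of the 3 values shown sit, holds both ends. Compound 3 `CCOC(=O)c1c(-c2cccc(OC)c2)[nH]c2cc(Cl)c(Cl)cc2c1=O` carries a core whose difference from that of compound 1 is not broken down here. In this assay compound 3 gives > 21500 nM, a limit as well. Compound 4 `CCOC(=O)c1c(-c2cccc(Oc3ccccc3)c2)[nH]c2cc(Cl)c(Cl)cc2c1=O` is not yet measured; it differs from compound 3 by phenyl in place of methyl on an oxygen on an aromatic ring, the same change as between compound 1 and compound 2, made at an identical place. With every measured value sitting at the same limit, and the earlier step unreadable, the step from compound 3 to compound 4 is expected to be small, about a step that the limit leaves unreadable from compound 3 to compound 4. Compound 4 is accordingly expected to return a value near 25000 nM, most likely reported only as a limit, within 10000 nM to 70000 nM.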

Compound 4, half-maximal effective concentration: > 21500 nM
Compound 4: no number, only a limit; the forecaster's own chance of this, stated with the estimate: 80%; the middle value does not contradict the limit.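

In this assay no new step can be read between compound 3 and compound 4, because both values are limits of the assay and not numbers: the limit of > 21500 nM in this assay, at which 4 of the 4 values shown sit. The compounds shown leave open how much of any of the four compounds is needed for the effect, and whether methoxy to phenoxy changes that amount on either core.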